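The source may report more compounds than this note shows. Statements on the series, on what has been measured and on what is new or still open speak of the compounds shown alone.

Three compounds have been measured so far in a functional assay on PC-3 cells (Homo sapiens) for cytotoxicity, read by MTT assay, with a stated time of 48 h; a higher number here means a weaker inhibitor, a lower number a stronger inhibitor:

Compound 1 `COc1cc(-c2nnc3n2NC(c2ccco2)C(C(=O)C2CC2)S3)cc(OC)c1OC`: 95200 nM
Compound 2 `COc1cc(-c2nnc3n2NC(c2ccco2)C(C(=O)c2ccccc2F)S3)cc(OC)c1OC`: > 100000 nM, a limit of the assay rather than a number
Compound 3 `COc1cc(-c2nnc3n2NC(c2ccco2)C(C(=O)c2ccc(-c4ccccc4)cc2)S3)cc(OC)c1OC`: 45900 nM

All three share one core and differ only in the group attached to a carbonyl carbon. Among the two actual numbers, compound 3 gives the lowest; its nearest neighbour is compound 1, and the change from one to the other is a 2.1-fold lower number from compound 1 to compound 3 (0.32 log units; beyond the scatter). For compound 2 the assay reports only a limit, so no number is known. Moving from compound 1 to compound 2 amounts to an at least 1.0-fold higher number from compound 1 to compound 2 (0.02 log units; that floor lies within the scatter), and from compound 2 to compound 3 to an at least 2.1-fold lower number from compound 2 to compound 3 (0.33 log units; beyond the scatter). Both steps that reach compound 3 replace a smaller group with 4-phenylphenyl and both lower the number modestly.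

Compound 4 `COc1cc(-c2nnc3n2NC(c2ccco2)C(C(=O)c2cccc4ccccc24)S3)cc(OC)c1OC` is not yet measured. It differs from compound 3 by naphthalen-1-yl in place of 4-phenylphenyl on a carbonyl carbon. The entering group, like the leaving one, consists of two six-membered aromatic rings of carbon only, so the closest guide is the pair of modest steps just described, and no step beyond the scatter is expected. The number expected for compound 4 in this assay is 50000 nM, within a range from 20000 nM to 100000 nM. This estimate corresponds to a step of a 1.1-fold higher number from compound 3 to compound 4 (0.04 log units; within the scatter).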

Compound 4, half-maximal inhibitory concentration: > 100000 nM
Compound 4: only a limit was reported; the forecaster's own chance of this, stated with the estimate: 20%; middle value at least 2.0-fold (0.30 log units) away from the limit.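

On this carbonyl carbon, naphthalen-1-yl in place of 4-phenylphenyl gives an at least 2.1-fold higher number from compound 3 to compound 4 (0.33 log units; beyond the scatter) in this assay, even though both groups consist of two six-membered aromatic rings of carbon only. Two such rings on this carbon are therefore not enough to give a measurable number, and among the compounds shown, the lower number of compound 3 goes with 4-phenylphenyl alone. Against cyclopropyl, the same change gives an at least 1.0-fold higher number from compound 1 to compound 4 (0.02 log units; that floor lies within the scatter), so compound 4 cannot be separated from compound 1, and the step from compound 2 to compound 4 cannot be read, with both compounds sitting at one limit: the limit of > 100000 nM in this assay, at which 2 of the 4 values shown sit.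

On these data alone, how far compound 2 and compound 4 really lie above that limit stays unknown, as neither has an actual number. As far as these compounds go, it also remains open whether naphthalen-2-yl, 4-methoxyphenyl or 4-aminophenyl on this carbonyl carbon would behave like compound 3 or like compound 4 in this assay.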